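Trifluoromethyl for sulfamoyl on a thiourea aryl ring

A few compounds are considered here, and "the series" means these few. Any claim that something is new, unique, unknown or untested is made for them only; others in the source may bear on it.

Measured compounds:
compound 1, `CC1(C)CC(C)(C)c2cc(NC(=S)Nc3ccc(S(N)(=O)=O)cc3)ccc2O1`: 6900 nM
compound 2, `CC1(C)CCOc2ccc(NC(=S)Nc3ccc(OC(F)(F)F)cc3)cc21`: 4300 nM

Compound 1 carries a sulfamoyl group on the aryl ring of its thiourea, and in a functional assay on A2780 cells (Homo sapiens) for inhibition, with a stated time of 72 h (a higher number here means a weaker inhibitor, a lower number a stronger inhibitor), compound 1 gives 6900 nM. Compound 2, which carries a trifluoromethoxy group and a different saturated ring in its core, gives 4300 nM in this assay; the two numbers do not differ beyond the usual scatter, so they say nothing about order between them. Compound 3, `CC1(C)CC(C)(C)c2cc(NC(=S)Nc3ccc(C(F)(F)F)cc3)ccc2O1`, is the unmeasured partner of compound 1. It differs by trifluoromethyl in place of sulfamoyl on an aromatic carbon. Going by the values given here, no measured pair shows this exchange, so the size of the step is unknown; the only guide is that both measured compounds, with differing groups at the same place, sit in a similar range. Compound 3 is therefore expected to give about 4500 nM in this assay, with a range from 1500 nM to 14000 nM, an expected step of a 1.5-fold lower number from compound 1 to compound 3 (0.19 log units; within the scatter) that could fall within the scatter.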

Compound 3, half-maximal inhibitory concentration: 43700 nM
Estimate against measurement, compound 3: 9.7-fold (0.99 log units) below; measured number above the stated range.
By their numbers in this assay, from the lowest: compounds 2 and 1 (each within the scatter of the next); then compound 3.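

On the aromatic carbon para to a large group, the shared core does respond to what is placed there: in this assay, trifluoromethyl in place of sulfamoyl gives a 6.3-fold higher number from compound 1 to compound 3 (0.80 log units; beyond the scatter), so compound 3 is the weaker inhibitor of this pair. The two groups have the same count of 4 heavy atoms, so heavy-atom count alone does not separate them, although sulfamoyl has hydrogen-bond donors and acceptors and trifluoromethyl has none. Nothing measured here explains the difference between them.

A single exchange cannot show whether the hydrogen-bond donor, the acceptors or some other difference between the groups goes with the step, and an amine, a carboxylic acid or a methyl sulfone at this place would be needed to test this. As far as these compounds go, how trifluoromethoxy behaves on the core of compound 1 also remains open.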